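Aryl swaps on the acylurea end and growth inhibition

A few compounds are considered here, and "the series" means these few. Any claim that something is new, unique, unknown or untested is made for them only; others in the source may bear on it.

Measured compounds:
compound 1 `CN(C(=O)NC(=O)c1ccc(Cl)cc1Cl)c1nc(C(F)(F)F)c(C(=O)N/N=C/c2cccc(C(F)(F)F)c2)s1` — 10.7 ug/mL
compound 2 `CN(C(=O)NC(=O)c1ccc(C(F)(F)F)cc1)c1nc(C(F)(F)F)c(C(=O)N/N=C/c2cccc(C(F)(F)F)c2)s1` — 8.95 ug/mL
compound 3 `CN(C(=O)NC(=O)c1ccc(F)c(F)c1)c1nc(C(F)(F)F)c(C(=O)N/N=C/c2cccc(C(F)(F)F)c2)s1` — 4.15 ug/mL

All three share one core and differ only in the aryl group on the acylurea carbonyl. In a functional assay on MCF7 cells (Homo sapiens) for inhibition, read by MTT assay, with a stated time of 72 h (a higher number here means a weaker inhibitor, a lower number a stronger inhibitor), compound 1 gives 10.7 ug/mL, compound 2 gives 8.95 ug/mL and compound 3 gives 4.15 ug/mL. Compound 3 stands lowest of the three: its step from compound 2 is a 2.2-fold lower number from compound 2 to compound 3 (0.33 log units; beyond the scatter) and from compound 1 is a 2.6-fold lower number from compound 1 to compound 3 (0.41 log units; beyond the scatter), both beyond the scatter, while a 1.2-fold lower number from compound 1 to compound 2 (0.08 log units; within the scatter) lies within it.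

Compound 4 `CN(C(=O)NC(=O)c1ccc([N+](=O)[O-])cc1)c1nc(C(F)(F)F)c(C(=O)N/N=C/c2cccc(C(F)(F)F)c2)s1` is not yet measured. It differs from compound 3 in one place: 4-nitrophenyl in place of 3,4-difluorophenyl on a carbonyl carbon. Among the compounds with values here, no measured step introduces a nitro group, so the three aryl steps above are the only guide; they show that changing this aryl moves this assay only modestly, and that compound 3 holds the lowest number so far. A return toward the numbers of compound 1 and compound 2 is therefore expected, a step upward of modest size, a 1.7-fold higher number from compound 3 to compound 4 (0.23 log units; within the scatter). Compound 4 is estimated at 7 ug/mL, within 3 ug/mL to 16 ug/mL.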

Compound 4, half-maximal inhibitory concentration: 4.39 ug/mL
Beside the measured number, compound 4's estimate is 1.6-fold (0.20 log units) above it; measured number inside the range.
By their numbers in this assay, from the lowest: compounds 3 and 4 (each within the scatter of the next); then compounds 2 and 1 (each within the scatter of the next).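

In this assay the 4-nitrophenyl group, on a carbonyl carbon whose other neighbour is an amide-type nitrogen, reads level with 3,4-difluorophenyl, with a 1.1-fold higher number from compound 3 to compound 4 (0.02 log units; within the scatter) as the step, so the low end of this short series no longer rests on 3,4-difluorophenyl alone. The result also gives a cleaner exchange at this position than the earlier aryl swaps, since nitro in place of trifluoromethyl on an aromatic carbon is a 2.0-fold lower number from compound 2 to compound 4 (0.31 log units; beyond the scatter) and is modest but beyond the scatter, while the wider change from 2,4-dichlorophenyl is a 2.4-fold lower number from compound 1 to compound 4 (0.39 log units; beyond the scatter) and is of similar modest size. No measurement available here accounts for why these groups fall where they do.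

The compounds shown leave open how an amine or a carboxylic acid on this phenyl ring, or a longer alkyl chain in place of the ring, would read in this assay and whether the level of compound 3 and compound 4 would hold. From the compounds shown here alone, all four compounds also keep the rest of the shared core unchanged, so it remains open whether this aryl order would survive a change elsewhere in the molecule.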